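Chloro to methyl on the pyrazole of compound 3

The source may hold more compounds than are shown below. What is called first, only, known or untested is meant among the compounds shown, and "the series" means these compounds.

Compound 3 `C[C@@H]1CCCN1c1c(C#N)c2c(N)nc(Nc3cn(C)nc3Cl)nc2n1C` gives 54 nM in an assay on HEK293 cells for inhibition of Leucine-rich repeat serine/threonine-protein kinase 2 variant G2019S (Homo sapiens), with a stated time of 48 h (a lower number here means a stronger inhibitor, a higher number a weaker inhibitor), the lowest of the two single numbers given. Its nearest neighbour is compound 1 `Cc1c(Nc2nc(N)c3c(C#N)c(N4CCC[C@H]4C)n(C)c3n2)cnn1C`, with 260 nM; the step from one to the other, a 4.8-fold lower number from compound 1 to compound 3 (0.68 log units; beyond the scatter), is beyond the scatter. Compound 2 `Cc1nn(C2CCOC2)cc1Nc1nc(N)c2c(C#N)c(N3CCC[C@H]3C)n(C)c2n1` has several entries, 65 nM; 180 nM (2 entries), and so carries no single number (the several entries of compound 2 in this assay, 65 nM; 180 nM (2 entries)).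

Compound 4 `Cc1nn(C)cc1Nc1nc(N)c2c(C#N)c(N3CCC[C@H]3C)n(C)c2n1` has not been measured. It differs from compound 3 by methyl in place of chloro on an aromatic carbon; cut one bond further out, this reads 3-chloro-1-methyl-1H-pyrazol-4-yl to 1,3-dimethyl-1H-pyrazol-4-yl. Among the measured compounds shown here, the only measured step that touches this exchange is the one from compound 1 to compound 3, where a chloro-bearing pyrazole replaced a methyl-bearing one and the number fell modestly; compound 4 returns to a methyl-bearing pyrazole, though the methyl sits on a different ring carbon than in compound 1, so the step is not the same one reversed. Compound 4 is therefore expected to lie between compound 3 and compound 1, with a step of a 2.2-fold higher number from compound 3 to compound 4 (0.35 log units; beyond the scatter) toward a higher number. The estimate for compound 4 in this assay is 120 nM, within a range of 50 nM to 300 nM.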

Compound 4, half-maximal inhibitory concentration: 120 nM
Compound 4: middle estimate and measured number agree at the digits printed, within the range that was stated.
By their numbers in this assay, from the lowest: compound 3; then compound 4; then compound 1.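

In this assay, the exchange at this aromatic carbon can now be read alone. The step from compound 1 to compound 3 changed both the identity of the group and the ring carbon that carried it. Here, a 2.2-fold higher number from compound 3 to compound 4 (0.35 log units; beyond the scatter) shows that chloro carries the lower number when methyl replaces it on the same carbon, while a 2.2-fold lower number from compound 1 to compound 4 (0.34 log units; beyond the scatter) shows that the placement of the methyl also matters, since the 1,3-dimethyl-1H-pyrazol-4-yl compound has a lower number than the 1,5-dimethyl-1H-pyrazol-4-yl compound. The earlier step thus divides into two modest steps, each beyond the scatter, but nothing given here explains either of them.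

With only chloro and methyl compared at this carbon, the compounds shown leave open how an ethyl group, a methoxy group or an amine would fare there, and two groups cannot establish a trend. They also leave open how the group on the ring nitrogen acts alongside this exchange, since compound 2, the only compound shown with a different group there, has no single number to compare: the several entries of compound 2 in this assay, 65 nM; 180 nM (2 entries)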